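Replacing a Hydroxy with a Cyano on the Outer Ring

The source may hold more compounds than are shown below. What is called first, only, known or untested is meant among the compounds shown, and "the series" means these compounds.

Three compounds share one core and differ at the outer aromatic ring and at the chain end. In an assay on SH-SY5Y cells for inhibition of Voltage-dependent N-type calcium channel subunit alpha-1B (Homo sapiens), read by FLIPR and calcium flux, with stated times of 600 s and 300 s, in the presence of a further agent that is not named here (a lower number here means a stronger inhibitor, a higher number a weaker inhibitor), compound 1 `CN(Cc1ccc(OCCCN)cc1)c1nc2ccc(Oc3ccc(C#N)cc3)cc2s1` gives 65000 nM, compound 2 `CN(Cc1ccc(OCCCNC(=N)N)cc1)c1nc2ccc(Oc3ccc(F)cc3)cc2s1` gives 100000 nM, and compound 3 `CN(Cc1ccc(OCCCNC(=N)N)cc1)c1nc2ccc(Oc3ccc(O)cc3)cc2s1` gives 432000 nM, the highest of the three numbers and so the weakest inhibitor shown. Compound 4 `CN(Cc1ccc(OCCCNC(=N)N)cc1)c1nc2ccc(Oc3ccc(C#N)cc3)cc2s1` arises from compound 3 by a single change: cyano in place of hydroxy on an aromatic carbon. Among the measured compounds shown here, the one measured step at this position is a 4.3-fold higher number from compound 2 to compound 3 (0.64 log units; beyond the scatter), and compound 1, which also carries the cyano group, sits well below compound 3. Undoing the hydroxy step is therefore expected to lower the number, by an estimated 5.1-fold lower number from compound 3 to compound 4 (0.71 log units; beyond the scatter). Compound 4 is thus expected to give 85000 nM in this assay, with a range from 30000 nM to 250000 nM.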

Compound 4, half-maximal inhibitory concentration: 143000 nM
Compound 4: the middle estimate sits 1.7-fold (0.23 log units) below what was measured; measured number inside the range.
By their numbers in this assay, from the lowest: compounds 1, 2 and 4 (each within the scatter of the next, the first and the last beyond it); then compound 3.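

In this assay, moving from hydroxy to cyano on the outer ring gives a 3.0-fold lower number from compound 3 to compound 4 (0.48 log units; beyond the scatter) and the change from fluoro to cyano gives a 1.4-fold higher number from compound 2 to compound 4 (0.16 log units; within the scatter), which is within the scatter, so those two groups cannot be told apart here. Compound 4 also isolates the chain end with the cyano group held fixed: adding the group of 3 heavy atoms on the amine nitrogen gives a 2.2-fold higher number from compound 1 to compound 4 (0.34 log units; beyond the scatter), a modest step. Nothing available explains either difference. On these data alone, the effects of a methoxy group or an amine on the outer ring remain open, as does the effect of a longer chain.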